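Tail amine swap in the bromophenyl series

The compounds below may be only part of what the source reports. "The series", "measured", "known", "first", "only" and "open" are said of these compounds alone.

Compound 1 `COc1cc2c(Oc3ccc(NC(=O)c4nn(-c5ccc(Br)cc5)c(=O)c5ccccc45)cc3F)ccnc2cc1OCCCN1CCN(C)CC1` is the starting point of this pair. In a functional assay on MKN-45 cells (Homo sapiens) for cytotoxicity, read by MTT assay, with a stated time of 72 h (on this read-out lower numbers stand for stronger inhibition and higher numbers for weaker inhibition), compound 1 gives 350 nM, the lowest of the two numbers seen so far. Among the compounds with values here, its only measured neighbour is compound 2 `COc1cc2c(Oc3ccc(NC(=O)c4nn(-c5ccc([N+](=O)[O-])cc5)c(=O)c5ccccc45)cc3F)ccnc2cc1OCCCN1CCN(C)CC1`, which in this assay gives 1320 nM; the step is a 3.8-fold higher number from compound 1 to compound 2 (0.58 log units; beyond the scatter), a change at the aryl ring that carries the bromo group.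

Compound 3 `COc1cc2c(Oc3ccc(NC(=O)c4nn(-c5ccc(Br)cc5)c(=O)c5ccccc45)cc3F)ccnc2cc1OCCCN1CCCCC1` keeps the bromo group of compound 1 and changes the tail instead: piperidin-1-yl in place of 4-methylpiperazin-1-yl on a saturated chain carbon, three bonds along the chain from an oxygen on an aromatic ring. Within the data shown here, no measured step touches this tail; the one step available, from compound 1 to compound 2, concerns a different part of the molecule and so offers no direct guide. With the rest of the structure unchanged and no contrary evidence, the tail change is treated as neutral in this assay. The expected step is then a 1.1-fold higher number from compound 1 to compound 3 (0.06 log units; within the scatter), a move that should stay inside the scatter. Compound 3 is therefore estimated at 400 nM in this assay. The range for compound 3 is expected to run from an estimated 150 nM to an estimated 1000 nM.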

Compound 3, half-maximal inhibitory concentration: 500 nM
For compound 3 the middle estimate is 1.3-fold (0.10 log units) below the measured one; the range from low to high includes it.
By their numbers in this assay, from the lowest: compounds 1 and 3 (each within the scatter of the next); then compound 2.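

In this assay, the tail on a saturated chain carbon, three bonds along the chain from an oxygen on an aromatic ring, now has a measured step of its own (a 1.4-fold higher number from compound 1 to compound 3 (0.15 log units; within the scatter)), so compound 1 and compound 3 cannot be told apart at this position. In the bromophenyl series, a 4-methylpiperazin-1-yl ring with 2 hetero atoms and a piperidin-1-yl ring with 1 hetero atom thus give numbers within the scatter of each other, whereas the step at the aryl ring (a 3.8-fold higher number from compound 1 to compound 2 (0.58 log units; beyond the scatter)) lies beyond it. No available evidence speaks to the reason for this result.

The compounds shown leave open whether the tail swap would read the same with the nitro group of compound 2 on the aryl ring, since both tails are compared here only with the bromo group. Also open, going by these compounds, is how a morpholin-4-yl ring, a dimethylamino group or a chain longer than the 3-(piperidin-1-yl)propyl chain would read at this position.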